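The source may report more compounds than this note shows. Statements on the series, on what has been measured and on what is new or still open speak of the compounds shown alone.

Of the compounds shown here, two that share one core have numbers so far in a functional assay (lung) for inhibition, with Cavia porcellus as the target; on this read-out lower numbers stand for stronger inhibition and higher numbers for weaker inhibition. Compound 1 `O=C(O)CCCCc1cccc(OCc2ccc3ccccc3n2)c1` gives 370 nM, and compound 2 `CC(CCCc1cccc(OCc2ccc3ccccc3n2)c1)C(=O)O` gives 75 nM, the lower of the two numbers. Within the data shown here, the only measured step is a 4.9-fold lower number from compound 1 to compound 2 (0.69 log units; beyond the scatter), with methyl in place of hydrogen on a saturated chain carbon bound to a carbonyl carbon and a saturated chain carbon. Compound 3 `CCCC(CCC(=O)O)Cc1cccc(OCc2ccc3ccccc3n2)c1` has not yet been measured in this assay. Its difference from compound 2 is 1-(2-carboxyethyl)butyl in place of 3-carboxybutyl on a saturated chain carbon bound to an aromatic carbon, so 1-(2-carboxyethyl)butyl stands in place of 3-carboxybutyl on a saturated chain carbon bound to an aromatic carbon. The methyl step bears on this change only loosely, since neither measured compound carries the entering group. It does show that a single change on this chain can move the number by a modest amount, so a step of similar size is plausible, while its direction remains uncertain. A slight weakening is the tentative expectation, amounting to an estimated 1.6-fold higher number from compound 2 to compound 3 (0.20 log units; within the scatter). For compound 3 the expected value is 120 nM, within an estimated range of 30 nM to 480 nM.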

Compound 3, half-maximal inhibitory concentration: 70 nM
Estimate against measurement, compound 3: 1.7-fold (0.23 log units) above, within the range that was stated.
By their numbers in this assay, from the lowest: compounds 3 and 2 (each within the scatter of the next); then compound 1.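

Compound 2 and compound 3, which carry 3-carboxybutyl and 1-(2-carboxyethyl)butyl on a saturated chain carbon bound to an aromatic carbon, cannot be told apart in this assay, with a 1.1-fold lower number from compound 2 to compound 3 (0.03 log units; within the scatter), although the entering group has 9 heavy atoms and the leaving group 7. Set against compound 1, propyl in place of hydrogen on a saturated chain carbon bound to two saturated chain carbons gives a 5.3-fold lower number from compound 1 to compound 3 (0.72 log units; beyond the scatter), so a step beyond the scatter now appears with a larger group and at a different chain carbon from the one that carries the methyl in compound 2. No supporting evidence bears on why these numbers fall as they do.

What the compounds shown leave open is whether an ethyl or a butyl group on that same chain carbon would give a similar number, and whether methyl and propyl together on one chain would lower it further. They also leave open whether the carboxylic acid itself is needed, as nothing here shows a tetrazole or an amide in its place.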